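The source may hold more compounds than are shown below. What is called first, only, known or untested is meant among the compounds shown, and "the series" means these compounds.

Measured so far in a functional assay on BT-549 cells (Homo sapiens) for inhibition, read by sulforhodamine B assay, with a stated time of 48 h (on this read-out higher numbers stand for weaker inhibition of growth and lower numbers for stronger inhibition of growth), on this series:
- compound 1 `O=C(Cc1csc2nc(-c3ccc(Br)cc3)cn12)N/N=C/c1ccc(O)cc1` gives 56200 nM 
- compound 2 `COc1cccc(OC)c1/C=N/NC(=O)Cc1csc2nc(-c3ccc(Br)cc3)cn12` gives 33900 nM 

Among the measured compounds shown here, these are the only two values, and the single measured step, a 1.7-fold lower number from compound 1 to compound 2 (0.22 log units; within the scatter), does not separate them. Compound 2 therefore stands level with compound 1 and has no rank of its own.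

The next compound is compound 3 `O=C(Cc1csc2nc(-c3ccc(Br)cc3)cn12)N/N=C/c1ccc(Cl)cc1Cl`, reached through (2,4-dichlorophenyl in place of 2,6-dimethoxyphenyl on a carbon with a double bond to nitrogen). In words, this puts 2,4-dichlorophenyl in place of 2,6-dimethoxyphenyl on a carbon with a double bond to nitrogen. No group carrying chlorine has yet been measured at this place, so the guidance is thin. For the measured compounds named here, only one measured step bears on the change, the exchange at the same place, a 1.7-fold lower number from compound 1 to compound 2 (0.22 log units; within the scatter), and it stayed small. On that single step, no shift beyond the scatter is expected in this assay, in either direction. The expected step is a 1.0-fold lower number from compound 2 to compound 3 (0.01 log units; within the scatter), and a wide range is kept around it. For compound 3 the estimated value is 33000 nM (expected range 14000 nM to 70000 nM).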

Compound 3, concentration for total growth inhibition: 77600 nM
The estimate for compound 3 lay 2.4-fold (0.37 log units) below the measured number, and the stated range ends below it.
By their numbers in this assay, from the lowest: compounds 2, 1 and 3 (each within the scatter of the next, the first and the last beyond it).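

In this assay, the place on a carbon with a double bond to nitrogen now shows a step beyond the scatter, a 2.3-fold higher number from compound 2 to compound 3 (0.36 log units; beyond the scatter), though the step is only modest and rests on a single pair. The other new step, a 1.4-fold higher number from compound 1 to compound 3 (0.14 log units; within the scatter), stays within the scatter, so 2,4-dichlorophenyl is separated from 2,6-dimethoxyphenyl but not from 4-hydroxyphenyl, and the three groups do not fall into a clean order: only the two end members of the series stand apart, while compound 1 is level with both. No measured information bears on why this exchange moves the number, so the step stands as an observation only.

The exchange from compound 2 to compound 3 swaps two methoxy groups for two chlorines and alters where they sit on the ring, so the compounds shown cannot separate the kind of group from its placement. As far as these compounds go, a 2,6-dichlorophenyl group or an unsubstituted phenyl at this place would address that, and whether a basic amine or a carboxylic acid on the ring would move the number further remains open.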